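Shortening the Chain Back to a Hydroxamic Acid

A few compounds are considered here, and "the series" means these few. Any claim that something is new, unique, unknown or untested is made for them only; others in the source may bear on it.

Compound 1 `Nc1ncnc2c1c(-c1cnc3[nH]ccc3c1)nn2CC(=O)NO` carries a hydroxycarbamoyl group on the chain carbon bound to the aromatic nitrogen of the shared core. In a functional assay on A549 cells (Homo sapiens) for inhibition, read by MTT assay, with a stated time of 72 h (a lower number here means a stronger inhibitor, a higher number a weaker inhibitor), compound 1 gives only a limit, > 150000 nM. Compound 2 `CNC(=O)CCCCCCCn1nc(-c2cnc3[nH]ccc3c2)c2c(N)ncnc21` gives 51000 nM, the only firm number shown, and the step of an at least 2.9-fold lower number from compound 1 to compound 2 (0.46 log units; beyond the scatter) runs toward it. Compound 3 `Nc1ncnc2c1c(-c1cnc3[nH]ccc3c1)nn2CCC(=O)NO` differs from compound 2 by hydroxycarbamoyl in place of 5-(methylcarbamoyl)pentyl on a saturated chain carbon, two bonds along the chain from an aromatic nitrogen. Among the compounds with values here, only that measured step bears on this change, and it ran the other way, so compound 3 is expected to be weaker, with a 2.4-fold higher number from compound 2 to compound 3 (0.37 log units; beyond the scatter). The estimate for compound 3 is 120000 nM, within 40000 nM to 300000 nM. A result at the limit of > 150000 nM in this assay, at which 1 of the 2 values shown sits, is quite possible.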

Compound 3, half-maximal inhibitory concentration: > 150000 nM
Compound 3: no number, only a limit; the forecaster's own chance of this, stated with the estimate: 45%; at least 1.2-fold (0.09 log units) between middle value and limit.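

With compound 3, the change from 5-(methylcarbamoyl)pentyl to hydroxycarbamoyl gives an at least 2.9-fold higher number from compound 2 to compound 3 (0.46 log units; beyond the scatter); this number is a minimum, since compound 3 reports only a limit. The extra chain carbon in compound 3 therefore does not bring the short hydroxamic acid of compound 1 to a firm number in this assay. The step between those two compounds cannot be read, because both stop at the same limit: the limit of > 150000 nM in this assay, at which 2 of the 3 values shown sit.

Going by these compounds, how much weaker compound 3 truly is stays open. So does whether a hydroxamic acid on a longer chain, or a carboxylic acid on the short chain, would give a firm number.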